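The source may hold more compounds than are shown below. What is called first, only, known or untested is meant among the compounds shown, and "the series" means these compounds.

Working notes on the series. Compound 1 `CCC(C)(C)C(=O)N(O)Cc1cc(F)cc(F)c1F` and compound 2 `CCC(C)(C)C(=O)N(O)Cc1cc(F)c(F)c(F)c1` share one core and differ only in where the fluoro groups sit on the ring. In an ADME assay on microsomes from liver (Mus musculus) for metabolic stability, read by LC-MS, using NADPH (on this read-out higher numbers stand for fast clearance and lower numbers for slow clearance), compound 1 gives 75.3 uL/min, and in this assay compound 2 gives 87.8 uL/min; the two numbers lie within the scatter of each other, so neither stands apart.

Compound 3 `CCC(C)(C)C(=O)N(O)Cc1ccc(F)c(F)c1` follows from compound 2 by hydrogen in place of fluoro on an aromatic carbon. Among the compounds with values here, no measured pair shows this change, so the step is expected to stay small, with at most a slight rise: a 1.1-fold higher number from compound 2 to compound 3 (0.03 log units; within the scatter) is the estimated step. In this assay compound 3 is expected to give 95 uL/min, within 55 uL/min to 165 uL/min.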

Compound 3, intrinsic clearance in a liver preparation (reported as CLH), per the amount of preparation that the assay uses: 61.4 uL/min
Compound 3: middle estimate off by 1.5-fold (0.19 log units), on the high side; low and high end bracket the measured number.
By their numbers in this assay, from the lowest: compounds 3, 1 and 2 (each within the scatter of the next).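

In this assay, hydrogen in place of fluoro on this aromatic carbon, ortho to a fluoro group and meta to a large group, gives a 1.4-fold lower number from compound 2 to compound 3 (0.16 log units; within the scatter) and so does not move compound 3 clear of the scatter. This first measured pair for the change shows that the fluoro group here can go without a step that stands apart, at least with the other two fluoro groups' positions as in these compounds. Nothing available explains the size of this step.

On these data alone, whether a nitrile or a methoxy group on this carbon would give a step beyond the scatter remains open. So does whether removing fluoro from the other ring positions behaves alike.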